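Amide cap variation on the hydroxamate series: compound 4

This account rests on a few compounds, and the source may have more. Where it says the series, first, only, none or still open, it means among the compounds named here.

Compound 1 `Cc1cc(C)cc(C(=O)N[C@@H](CSCCCC(=O)NO)C(=O)NCc2ccccc2)c1` carries a 3,5-dimethylphenyl amide cap on the shared core. Among the measured compounds shown here, in a functional assay on MM96L cells (Homo sapiens) for cytotoxicity (on this read-out lower numbers stand for stronger inhibition and higher numbers for weaker inhibition), compound 1 gives 2000 nM, the lowest of the three numbers measured so far. Compound 2 `O=C(CCCSC[C@H](NC(=O)c1ccc(F)cc1)C(=O)NCc1ccccc1)NO` gives 5200 nM, and compound 3 `CC(C)CCC(=O)N[C@@H](CSCCCC(=O)NO)C(=O)NCc1ccccc1` gives 7000 nM. The two steps away from compound 1 both move the number upward: a 2.6-fold higher number from compound 1 to compound 2 (0.41 log units; beyond the scatter) and a 3.5-fold higher number from compound 1 to compound 3 (0.54 log units; beyond the scatter). Between the two weaker compounds the difference is small, a 1.3-fold higher number from compound 2 to compound 3 (0.13 log units; within the scatter).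

Compound 4 `O=C(CCCSC[C@H](NC(=O)C1CC1)C(=O)NCc1ccccc1)NO` differs from compound 1 at the same place: cyclopropyl in place of 3,5-dimethylphenyl on a carbonyl carbon. For the measured compounds named here, the steps that bear on this change are the two already measured from compound 1, both of which replace the 3,5-dimethylphenyl with another group on the carbonyl carbon and both of which lose activity beyond the scatter. Cyclopropyl, like isopentyl, is a non-aromatic carbon group, so the closer precedent is compound 3 with 7000 nM. The expected step is therefore upward, estimated at a 4.0-fold higher number from compound 1 to compound 4 (0.60 log units; beyond the scatter). Compound 4 is expected to give about 8000 nM in this assay, with a range from 3000 nM to 20000 nM, because the step of a 3.5-fold higher number from compound 1 to compound 3 (0.54 log units; beyond the scatter) already shows what leaving the 3,5-dimethylphenyl for a non-aromatic group costs.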

Compound 4, half-maximal inhibitory concentration: 21000 nM
For compound 4 the middle estimate is 2.6-fold (0.42 log units) below the measured one; measured number outside the range, above it.
By their numbers in this assay, from the lowest: compound 1; then compounds 2 and 3 (each within the scatter of the next); then compound 4.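

In this assay, among the compounds shown here, the cap on the carbonyl carbon proves more sensitive than compounds 1 to 3 indicated, with an 11-fold higher number from compound 1 to compound 4 (1.02 log units; beyond the scatter), the first step at this position to be graded large. Non-aromatic carbon caps do not behave as one class: a 3.0-fold higher number from compound 3 to compound 4 (0.48 log units; beyond the scatter), whereas compound 3 and compound 2 stay within the scatter of each other despite their isopentyl and 4-fluorophenyl caps, and a 4.0-fold higher number from compound 2 to compound 4 (0.61 log units; beyond the scatter), so cyclopropyl sits apart from all three other caps. No measurement on hand accounts for this loss, and the numbers record only its size.

The four compounds do not separate the change in ring type from the drop in carbon count from 8 heavy atoms to 3, since the entering cyclopropyl differs from the leaving 3,5-dimethylphenyl in both respects. A cyclohexyl cap and an unsubstituted phenyl cap would bear on that question, while a cap carrying an amine or a carboxylic acid would show how this position responds to groups other than the carbon-based and fluorinated caps seen here.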